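Methyl for hydrogen on the ring nitrogen of a weak antagonist

The source may hold more compounds than are shown below. What is called first, only, known or untested is meant among the compounds shown, and "the series" means these compounds.

Measured so far:
compound 1 `COc1cc2c(cc1NS(=O)(=O)c1cccc(Cl)c1Cl)[nH]c(=O)n2C`: 200 nM
compound 2 `COc1cc2[nH]c(=O)n(C)c2cc1NS(=O)(=O)c1cccc(Cl)c1Cl`: 20000 nM

Of the compounds shown here, two sharing one core have been measured in a functional assay on CHO cells for antagonist activity at C-C chemokine receptor type 4 (Homo sapiens), read by radioligand binding and GTPgammaS binding (a lower number here means a stronger inhibitor, a higher number a weaker inhibitor), and the numbers are far apart. Compound 1 gives 200 nM in this assay, whereas compound 2 gives 20000 nM. Compound 2 therefore stands at the weak end of the pair, with its step to compound 1 beyond the usual scatter.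

The next compound, compound 3 `COc1cc2c(cc1NS(=O)(=O)c1cccc(Cl)c1Cl)n(C)c(=O)n2C`, is compound 2 with one change: methyl in place of hydrogen on an aromatic nitrogen. Compound 3 thus carries a methyl group on both ring nitrogens of the core, so it has a feature of compound 1 as well as of compound 2. Only two measured points exist, so the direction of this change is uncertain. Because compound 1 gives 200 nM in this assay, a move towards a lower number is expected, but the wide range reflects how little is known. The step from a 10-fold lower number from compound 2 to compound 3 (1.00 log units; beyond the scatter) is estimated to lower the number beyond the scatter. Compound 3 is expected to give about 2000 nM in this assay, within a range from 200 nM to 20000 nM.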

Compound 3, half-maximal inhibitory concentration in the C-C chemokine receptor type 4 assay: 2000 nM
Compound 3: the middle estimate sits on the measured number at the digits printed, and the stated range covers the measured number.
By their numbers in the C-C chemokine receptor type 4 assay, from the lowest: compound 1; then compound 3; then compound 2.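

In the C-C chemokine receptor type 4 assay compound 3 gives 2000 nM and methyl in place of hydrogen on an aromatic nitrogen gives a 10-fold lower number from compound 2 to compound 3 (1.00 log units; beyond the scatter) on one ring nitrogen, but a 10-fold higher number from compound 1 to compound 3 (1.00 log units; beyond the scatter) on the other. The same small change therefore has no single direction on this core: whether the number falls or rises depends on which ring nitrogen receives the methyl, and compound 3, with methyl on both, sits between the other two. In a physicochemical assay for solubility, read by chemiluminescence, measured as kinetic solubility (a higher number here means a more soluble compound, a lower number a less soluble compound), compound 2 gives 66 ug/mL and compound 3 gives 58 ug/mL and the same change shows only a 1.1-fold lower number from compound 2 to compound 3 (0.06 log units; within the scatter) and so no real difference in solubility.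

As far as these compounds go, it remains open whether an ethyl group or a longer chain on either ring nitrogen would follow these same two directions. Nothing measured here gives a reason for the opposite outcomes at the two ring nitrogens.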